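Valyl in place of aspartyl ester on compound 2

The source may report more compounds than this note shows. Statements on the series, on what has been measured and on what is new or still open speak of the compounds shown alone.

Measured so far in an assay on cells (Oocyte) for inhibition of sodium- and chloride-dependent neutral and basic amino acid transporter B(0+) (Homo sapiens), read by LC-MS, with a stated time of 10 min; a higher number here means a weaker inhibitor, a lower number a stronger inhibitor:
compound 1 `N[C@@H](CCC(=O)OC[C@H]1O[C@@H](n2cc(F)c(=O)[nH]c2=O)C[C@@H]1OC(=O)CC[C@H](N)C(=O)O)C(=O)O` gives 2650000 nM
compound 2 `N[C@@H](CC(=O)OC[C@H]1O[C@@H](n2cc(F)c(=O)[nH]c2=O)C[C@@H]1O)C(=O)O` gives 820000 nM
compound 3 `N[C@@H](CC(=O)OC[C@H]1O[C@@H](n2cc(F)c(=O)[nH]c2=O)C[C@@H]1OC(=O)C[C@H](N)C(=O)O)C(=O)O` gives 2980000 nM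

Compound 2 holds the lowest of the three numbers in this assay. Among the compounds with values here, compound 1 and compound 3 both lie above it; the one counted step, a 3.6-fold higher number from compound 2 to compound 3 (0.56 log units; beyond the scatter), shows that adding a second ester to compound 2 raises the number beyond the scatter. Compound 1 is not linked to compound 2 by a counted step and only the two values can be compared.

Within the data shown here, compound 4 `CC(C)[C@H](N)C(=O)OC[C@H]1O[C@@H](n2cc(F)c(=O)[nH]c2=O)C[C@@H]1O` keeps the single ester of compound 2 and changes only the acyl part: 1-amino-2-methylpropyl in place of 2-amino-2-carboxyethyl on a carbonyl carbon.

Among the measured compounds shown here, none of the measured steps covers this change. For the measured compounds named here, the only step available, a 3.6-fold higher number from compound 2 to compound 3 (0.56 log units; beyond the scatter), concerns the addition of a whole second ester and says nothing about swapping one amino acid for another on the existing ester. With no bearing data, no step beyond the scatter is expected in this assay in either direction, and the number for compound 4 is expected to stay near that of compound 2.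

The estimated step is a 1.2-fold lower number from compound 2 to compound 4 (0.07 log units; within the scatter), with compound 4 expected at 700000 nM, within a range of 200000 nM to 2500000 nM.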

Compound 4, half-maximal inhibitory concentration: 980000 nM
Beside the measured number, compound 4's estimate is 1.4-fold (0.15 log units) below it; the range from low to high includes it.
By their numbers in this assay, from the lowest: compounds 2 and 4 (each within the scatter of the next); then compounds 1 and 3 (each within the scatter of the next).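

In this assay, replacing 2-amino-2-carboxyethyl with 1-amino-2-methylpropyl on the carbonyl carbon of the single ester gives a 1.2-fold higher number from compound 2 to compound 4 (0.08 log units; within the scatter), so the two acyl groups cannot be told apart at this position. Within the data shown here, the earlier compounds spoke only to the addition of a second ester; this pair is the first reading on the identity of the group on the existing ester, and it shows that the carboxylic acid carried by compound 2 and absent from compound 4 is not required for a number in this range, where compound 4 gives 980000 nM. No supporting data are available to account for this match.

Still open, from the compounds shown here alone, is what a group of a different kind would do on the same carbonyl carbon, such as a longer chain ending in an amine or a chain carrying a phenyl ring. Also open, going by these compounds, is whether 1-amino-2-methylpropyl, carried on a second ester, would follow the step seen from compound 2 to compound 3, a 3.6-fold higher number from compound 2 to compound 3 (0.56 log units; beyond the scatter).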